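Hydroxy in Place of Bromo on Two Cores

The source may report more compounds than this note shows. Statements on the series, on what has been measured and on what is new or still open speak of the compounds shown alone.

Compound 1 `COc1ccc(Cn2nncc2-c2cc(OC)c(OC)c(OC)c2)cc1Br`: > 10000 nM
Compound 2 `COc1ccc(Cn2nncc2-c2cc(OC)c(OC)c(OC)c2)cc1O`: 1830 nM
Compound 3 `COc1ccc(-c2cn(-c3cc(OC)c(OC)c(OC)c3)nn2)cc1Br`: > 10000 nM

In a functional assay on K562 cells (Homo sapiens) for cytotoxicity, read by MTT assay, with a stated time of 5 days (on this read-out higher numbers stand for weaker inhibition and lower numbers for stronger inhibition), compound 1 gives > 10000 nM, which is a limit of the assay and not a number. Compound 2 gives 1830 nM in the same test. The step of an at least 5.4-fold lower number from compound 1 to compound 2 (0.73 log units; beyond the scatter) follows the change (hydroxy in place of bromo on an aromatic carbon). Compound 3 gives > 10000 nM, again a limit. How the core of compound 3 differs from that of compound 1 is not broken down here. Compound 4 `COc1ccc(-c2cn(-c3cc(OC)c(OC)c(OC)c3)nn2)cc1O` carries the same change as compound 2, (hydroxy in place of bromo on an aromatic carbon), in the identical surroundings. Since compound 3 sits at the limit of > 10000 nM in this assay, at which 2 of the 3 values shown sit, only a floor for the step is known; he expects an at least 3.3-fold lower number from compound 3 to compound 4 (0.52 log units; beyond the scatter) in this assay, resting on an at least 5.4-fold lower number from compound 1 to compound 2 (0.73 log units; beyond the scatter). His estimate for compound 4 is 3000 nM, between 800 nM and 20000 nM.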

Compound 4, half-maximal inhibitory concentration: > 10000 nM
Compound 4 gave a limit, no number (the forecaster's own chance of this, stated with the estimate: 35%); middle value at least 3.3-fold (0.52 log units) away from the limit.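

Compound 3 and compound 4 both stand at the same limit, not at a number, so no step can be read between them: the limit of > 10000 nM in this assay, at which 3 of the 4 values shown sit.

As far as these compounds go, whether hydroxy in place of bromo acts on the core of compound 3 as it does on the core of compound 1 stays open.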